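A few compounds are considered here, and "the series" means these few. Any claim that something is new, unique, unknown or untested is made for them only; others in the source may bear on it.

Measured so far:
compound 1 `FC(F)(F)c1cccnc1-c1ccc2[nH]c(/C=C/C3CCCCC3)nc2c1`: 42%
compound 2 `FC1(F)CCC(/C=C/c2nc3cc(-c4ccccc4C(F)(F)F)ccc3[nH]2)CC1`: 39%

In an ADME assay on microsomes from liver (Canis lupus familiaris) for metabolic stability, with a stated time of 10 min (a lower number here means that less of the compound is left, a higher number that more of the compound is left), compound 1 gives 42% and compound 2 gives 39%. The gap between the two lies within the scatter, so compound 2 does not separate from compound 1 in this assay; the two numbers read as one level.

Compound 3 `FC(F)(F)c1ccccc1-c1ccc2[nH]c(/C=C/C3CCNCC3)nc2c1` is not yet measured. It differs from compound 2 by piperidin-4-yl in place of 4,4-difluorocyclohexyl on a double-bonded chain carbon bound to a double-bonded chain carbon. Going by the values given here, no pair of measured compounds differs in this place alone, so the direction of the change has no support in the numbers. For compound 3 the step of a number 6 percentage points higher from compound 2 to compound 3 (within the scatter) is expected to stay within the scatter. Compound 3 is estimated at 45% in this assay, with a range from 25% to 70%.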

Compound 3, percent of the compound remaining: 98%
Compound 3: middle estimate off by 53 percentage points, on the low side; the whole stated range lies below it.
By their numbers in this assay, from the lowest: compounds 2 and 1 (each within the scatter of the next); then compound 3.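

In this assay, piperidin-4-yl in place of 4,4-difluorocyclohexyl on a double-bonded chain carbon bound to a double-bonded chain carbon gives a number 59 percentage points higher from compound 2 to compound 3 (beyond the scatter). Going by these compounds alone, this is the first single change at this position with a reading, and it shows that the ring carried there can have a large effect on this read-out. Nothing measured here accounts for the step.

Whether the step belongs to the ring nitrogen itself remains open, as only this one exchange is shown at this position. From the compounds shown here alone, how a morpholine ring, a methyl group on the piperidine nitrogen or a carboxylic acid would read at this place is unknown.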